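The source may hold more compounds than are shown below. What is called first, only, known or untested is meant among the compounds shown, and "the series" means these compounds.

Compound 1 `Oc1ccc(-c2cc(-c3cccnc3)nc(-c3ccccc3Cl)c2)cc1` — "not determined" (no result reported)
Compound 2 `Oc1ccc(-c2cc(-c3ccccc3)nc(-c3ccccc3Cl)c2)cc1` — 4990 nM
Compound 3 `Oc1ccc(-c2cc(-c3ccco3)nc(-c3ccccc3Cl)c2)cc1` — 5460 nM

In a functional assay on HCT-15 cells (Homo sapiens) for cytotoxicity, read by CCK-8 assay and cell counting, with a stated time of 2 days (on this read-out lower numbers stand for stronger inhibition and higher numbers for weaker inhibition), compound 1 stands without a result, so there is no single number to start from. Within the data shown here, compound 2 gives 4990 nM in this assay and compound 3 gives 5460 nM; the one measured step, a 1.1-fold higher number from compound 2 to compound 3 (0.04 log units; within the scatter), lies within the scatter and concerns the group that sits where compound 1 carries its pyridin-3-yl group, not the chlorophenyl group.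

Compound 4 `Oc1ccc(-c2cc(-c3cccnc3)nc(-c3cccc(Cl)c3)c2)cc1` differs from compound 1 in one place: 3-chlorophenyl in place of 2-chlorophenyl on an aromatic carbon. Among the measured compounds shown here, no measured step touches the chlorophenyl group, so the measured steps give no direction for this change. For the measured compounds named here, with compound 1 unmeasured, the only anchors are compound 2 and compound 3, whose values sit close together, and the expectation for compound 4 rests on those two with a wide range. Compound 4 is therefore expected to give about 5500 nM in this assay, estimated to lie between 1500 nM and 20000 nM.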

Compound 4, half-maximal inhibitory concentration: 21300 nM
For compound 4 the middle estimate is 3.9-fold (0.59 log units) below the measured one; measured number above the stated range.
By their numbers in this assay, from the lowest: compounds 2 and 3 (each within the scatter of the next); then compound 4.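

In this assay, among these compounds, compound 1 gives "not determined" (no result reported), so no step from it to compound 4 can be read. The compounds shown leave open what 3-chlorophenyl in place of 2-chlorophenyl does to the number. No evidence given here bears on this result.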